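Series notes: adding another trifluoromethyl to compound 2

The source may report more compounds than this note shows. Statements on the series, on what has been measured and on what is new or still open speak of the compounds shown alone.

Compound 2 `CC1=C(/C=C/C(=O)/C=C/c2cccc(C(F)(F)F)c2)C(C)(C)CCC1O` holds the lowest number of the three compounds measured in a functional assay on LNCaP cells (Homo sapiens) for cytotoxicity, read by MTT assay, with a stated time of 72 h (on this read-out higher numbers stand for weaker inhibition and lower numbers for stronger inhibition), where compound 2 gives 740 nM. Compound 1 `CC1=C(/C=C/C(=O)/C=C/c2ccccc2)C(C)(C)CCC1O`, which carries no trifluoromethyl on its aromatic ring, gives 5800 nM in this assay, and compound 3 `CC1=C(/C=C/C(=O)/C=C/c2cc(C(F)(F)F)ccc2C(F)(F)F)C(C)(C)CCC1O` gives 3200 nM. The two measured steps run in opposite directions: a 7.8-fold lower number from compound 1 to compound 2 (0.89 log units; beyond the scatter), whereas a 4.3-fold higher number from compound 2 to compound 3 (0.64 log units; beyond the scatter).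

Compound 4 `CC1=C(/C=C/C(=O)/C=C/c2cc(C(F)(F)F)cc(C(F)(F)F)c2)C(C)(C)CCC1O` differs from compound 2 in one place: trifluoromethyl in place of hydrogen on an aromatic carbon. Both measured steps bear on this change, since each is a trifluoromethyl replacing hydrogen on the aromatic ring. The closer analogy is the step from compound 2 to compound 3, in which a trifluoromethyl enters a ring that already carries one; that step raised the number in this assay, though compound 3 places its new group differently from compound 4. The step from compound 1 to compound 2 shows the opposite direction on a ring without a trifluoromethyl. On balance a rise beyond the scatter is expected, but smaller than the step to compound 3. For compound 4 the expected value in this assay is 2000 nM, with a range from 800 nM to 5000 nM. The expected step is therefore a 2.7-fold higher number from compound 2 to compound 4 (0.43 log units; beyond the scatter).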

Compound 4, half-maximal inhibitory concentration: 2100 nM
Compound 4: middle estimate off by 1.1-fold (0.02 log units), on the low side; measured number inside the range.
By their numbers in this assay, from the lowest: compound 2; then compounds 4, 3 and 1 (each within the scatter of the next, the first and the last beyond it).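

On the ring of compound 2, a trifluoromethyl placed meta to a trifluoromethyl group and meta to a large group also raises the number in this assay, with a 2.8-fold higher number from compound 2 to compound 4 (0.45 log units; beyond the scatter), so the rise seen earlier with compound 3 is not confined to a single placement of the added group. Compound 4 at 2100 nM and compound 3 at 3200 nM lie within the scatter of each other, so these two placements cannot be told apart on this read-out. The gain that came with the first trifluoromethyl therefore does not continue with another on either of these two compounds, and compound 2 keeps the lowest number of the series.

No measurement at hand accounts for this reversal in direction. The compounds shown leave open whether the rise is particular to trifluoromethyl or would also follow with another group, such as a chlorine atom, a methoxy group or a nitrile, at the same place on the ring of compound 2.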